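The source may hold more compounds than are shown below. What is called first, only, known or untested is meant among the compounds shown, and "the series" means these compounds.

Measured compounds:
Compound 1 `COc1cc(-c2nn(-c3cccc(NC(=O)c4cccc(C(F)(F)F)c4)c3)cc2-c2ccncc2)ccc1Cl`: in a functional assay on RPMI-8226 cells (Homo sapiens) for inhibition, read by sulforhodamine B assay, with a stated time of 48 h (a higher number here means a weaker inhibitor of growth, a lower number a stronger inhibitor of growth), compound 1 gives 1570 nM.
Compound 2 `COc1cc(-c2nn(-c3cccc(NC(=O)c4ccc(Cl)c(C(F)(F)F)c4)c3)cc2-c2ccncc2)ccc1Cl`: compound 2 gives 1620 nM.
Compound 3 `COc1cc(-c2nn(-c3cccc(NC(=O)Nc4ccc(Cl)c(C(F)(F)F)c4)c3)cc2-c2ccncc2)ccc1Cl`: compound 3 gives 868 nM.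

All three compounds share the same core and differ only in the group attached to the carbonyl carbon of the amide. Compound 3 sits at the lower end of the three numbers, yet its steps to the other two are within the scatter: a 1.8-fold lower number from compound 1 to compound 3 (0.26 log units; within the scatter) and a 1.9-fold lower number from compound 2 to compound 3 (0.27 log units; within the scatter). The chloro addition, a 1.0-fold higher number from compound 1 to compound 2 (0.01 log units; within the scatter), changed nothing measurable.

Compound 4 `COc1cc(-c2nn(-c3cccc(NC(=O)c4ccccc4)c3)cc2-c2ccncc2)ccc1Cl` is not yet measured. Going from compound 3 to compound 4 means (phenyl in place of (4-chloro-3-(trifluoromethyl)phenyl)amino on a carbonyl carbon). Two parts of that change have some precedent: the urea-to-amide switch, seen in reverse between compound 1 and compound 3, gave only a small within-scatter shift, and the chloro made no difference between compound 1 and compound 2. Loss of the trifluoromethyl group has no precedent here, so a number near compound 1, perhaps somewhat higher, is expected for compound 4: a 2.5-fold higher number from compound 3 to compound 4 (0.40 log units; beyond the scatter).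

Compound 4 is estimated at 2200 nM, within 900 nM to 5500 nM.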

Compound 4, concentration for 50% growth inhibition: 850 nM
Estimate against measurement, compound 4: 2.6-fold (0.41 log units) above, outside the stated range (below it).
By their numbers in this assay, from the lowest: compounds 4, 3, 1 and 2 (each within the scatter of the next).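

In this assay the group on the carbonyl carbon can be cut back to a plain phenyl, without the urea nitrogen, the chloro or the trifluoromethyl, and no readable loss follows (a 1.0-fold lower number from compound 3 to compound 4 (0.01 log units; within the scatter)). Bare phenyl also stays within the scatter when the chloro and trifluoromethyl go together (a 1.9-fold lower number from compound 2 to compound 4 (0.28 log units; within the scatter)) and when the trifluoromethyl goes alone (a 1.8-fold lower number from compound 1 to compound 4 (0.27 log units; within the scatter)), so none of these groups is needed for this level of growth inhibition. No measurement at hand bears on why the number holds.

All four numbers lie within the scatter of one another, so nothing shown yet moves the read-out through this position. Going by these compounds, whether an amine, a carboxylic acid or a longer chain on the carbonyl carbon would shift growth inhibition remains open.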